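The source may hold more compounds than are shown below. What is called first, only, known or untested is meant among the compounds shown, and "the series" means these compounds.

Compound 1 `CCCCCCCCCCCCCCC[C@@H](C[C@@H](O)C[C@@H](O)C[C@@H](O)C[C@@H](O)C[C@H]1CC=CC(=O)O1)OC(C)=O`: 2900 nM
Compound 2 `CCCCCCCCCCCCCCC[C@H](C[C@H](O)C[C@H](O)C[C@H](O)C[C@H](O)C[C@@H]1CC=CC(=O)O1)OC(C)=O`: 2400 nM

Both compounds were tested in a functional assay on HT-29 cells (Homo sapiens) for cytotoxicity, read by MTT assay, with a stated time of 72 h; on this read-out higher numbers stand for weaker inhibition and lower numbers for stronger inhibition. Compound 2 gives 2400 nM, and only compound 1 stands beside it, so there is little to rank it against. For the measured compounds named here, the single measured comparison is a 1.2-fold lower number from compound 1 to compound 2 (0.08 log units; within the scatter). These two compounds differ only in the configuration as drawn (the fact that compounds 1 and 2 differ only in the configuration as drawn), being mirror images, so inverting every stereocentre left no separation in this assay.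

The next compound is compound 3 `CCCCCCCCCCCCCCC[C@@H](O)C[C@H](O)C[C@H](O)C[C@H](O)C[C@H](O)C[C@@H]1CC=CC(=O)O1`. It keeps the configuration of compound 2 but changes one group: hydrogen in place of acetyl on an oxygen on a saturated carbon. In short, acetoxy becomes hydroxy.

Going by the values given here, the one measured step, a 1.2-fold lower number from compound 1 to compound 2 (0.08 log units; within the scatter), leaves the acetyl in place, so it gives no direct size for this change. With nothing measured that points either way, no step beyond the scatter is expected, though the uncertainty is wide. The expected change is a 1.3-fold higher number from compound 2 to compound 3 (0.10 log units; within the scatter). For compound 3 the estimated value is 3000 nM, within an expected range of 1000 nM to 10000 nM.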

Compound 3, half-maximal inhibitory concentration: 4100 nM
Beside the measured number, compound 3's estimate is 1.4-fold (0.14 log units) below it; measured number inside the range.
By their numbers in this assay, from the lowest: compounds 2, 1 and 3 (each within the scatter of the next).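

Taking the acetyl off the oxygen on a saturated carbon, so that acetoxy becomes hydroxy, gives the first measured look at this position: in this assay the step is a 1.7-fold higher number from compound 2 to compound 3 (0.23 log units; within the scatter) and does not separate the two compounds. The earlier pair showed only that inverting every stereocentre left the read-out unseparated, whereas this pair shows that the acetyl group itself, with its three heavy atoms, is not required for a read-out in this range, at least in the configuration of compound 2. Nothing known about these compounds bears on why acetoxy and hydroxy read alike here, so this result comes with no explanation.

The compounds shown leave open whether a different group on this oxygen, such as a methyl ether or a benzoyl ester, would move the number beyond the scatter. On these data alone, they also leave open whether the mirror image of compound 3 would stay as close to compound 3 as compound 1 stays to compound 2, so the link between configuration and the acetyl group remains untested.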